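Shortening the isobutyl group of compound 3 to propyl

The source may hold more compounds than are shown below. What is called first, only, known or untested is meant among the compounds shown, and "the series" means these compounds.

In an ADME assay on microsomes from liver (Rattus norvegicus) for metabolic stability (a lower number here means slower removal, a higher number faster removal of the compound), compound 3 `CC(C)CC(Oc1ccc(-n2cc(C(F)(F)F)cn2)cc1)c1ccc(C(=O)NCCC(=O)O)cc1` gives 46 mL/min/kg. Compound 2 `CC(C)(C)C(Oc1ccc(-n2cc(C(F)(F)F)cn2)cc1)c1ccc(C(=O)NCCC(=O)O)cc1` gives 28 mL/min/kg, and the measured step is a 1.6-fold higher number from compound 2 to compound 3 (0.22 log units; within the scatter). Compound 1 `O=C(O)CCNC(=O)c1ccc(C(Oc2ccc(-n3cc(C(F)(F)F)cn3)cc2)C2CCC2)cc1` reads < 25 mL/min/kg, which is a limit of the assay and not a number. Compound 4 `CCCC(Oc1ccc(-n2cc(C(F)(F)F)cn2)cc1)c1ccc(C(=O)NCCC(=O)O)cc1` has hydrogen in place of methyl on a saturated chain carbon bound to two saturated chain carbons, which turns isobutyl into propyl. The nearest evidence comes from group swaps at the carbon carrying these chains: a 1.6-fold higher number from compound 2 to compound 3 (0.22 log units; within the scatter) and an at least 1.8-fold higher number from compound 1 to compound 3 (0.26 log units; that floor lies within the scatter). Neither lies beyond the scatter, so no larger step is expected here. The expected change is a 1.3-fold lower number from compound 3 to compound 4 (0.11 log units; within the scatter). For compound 4 the estimated clearance is 36 mL/min/kg, with an expected range of 20 mL/min/kg to 62 mL/min/kg.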

Compound 4, clearance in the Rattus norvegicus assay: < 36 mL/min/kg
Compound 4: no number, only a limit; the forecaster's own chance of this, stated with the estimate: 20%; the middle value lies on the limit itself.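

In the Rattus norvegicus assay, hydrogen in place of methyl gives an at least 1.2-fold lower number from compound 3 to compound 4 (0.10 log units; that floor lies within the scatter). The reading for compound 4 is a limit, so this is only a floor on the step, and the steps from compound 1 and compound 2 to compound 4 cannot be read. In a physicochemical assay for lipophilicity, using the shake flask method, at pH 7.4 (on this read-out higher numbers stand for higher lipophilicity and lower numbers for lower lipophilicity), compound 3 (3.2) and compound 4 (2.4) were also measured, and the same change gives the first step here that lies beyond the scatter: the measured distribution coefficient of compound 3, 3.2, and of compound 4, 2.4, a number 0.80 log units lower (beyond the scatter)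

On these data alone, how far the clearance of compound 4 truly differs from that of compound 3 stays open. So does what an ethyl group or a chain ending in an amine would do in place of the propyl group.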